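Estimating Compound 4 from Three Measured Analogues

The source may hold more compounds than are shown below. What is called first, only, known or untested is meant among the compounds shown, and "the series" means these compounds.

Compound 3 `COc1ccc(Oc2ccc([C@H]3S[C@@H](C)C(=O)Nc4c3c(C)nn4-c3ccccc3C)cc2)cc1` gives 2200 nM in an assay on isolated protein for agonist activity at Bile acid receptor (Homo sapiens), read by AlphaScreen, with a stated time of 30 min (a lower number here means that less compound is needed, a higher number that more compound is needed for the effect), the second highest of the three numbers. Compound 1 `Cc1ccccc1-n1nc(C)c2c1NC(=O)[C@H](C)S[C@@H]2c1ccc(-c2ccoc2)cc1` gives 3500 nM, and compound 2 `COc1ccccc1-c1ccc([C@H]2S[C@@H](C)C(=O)Nc3c2c(C)nn3-c2ccccc2C)cc1` gives 1100 nM. Around compound 3, a 1.6-fold lower number from compound 1 to compound 3 (0.20 log units; within the scatter) and a 2.0-fold higher number from compound 2 to compound 3 (0.30 log units; within the scatter) both stay within the scatter, while a 3.2-fold lower number from compound 1 to compound 2 (0.50 log units; beyond the scatter) is modest. Compound 4 `CCOc1cccc(-c2ccc([C@H]3S[C@@H](C)C(=O)Nc4c3c(C)nn4-c3ccccc3C)cc2)c1` carries 3-ethoxyphenyl in place of 4-methoxyphenoxy on an aromatic carbon. Within the data shown here, the step that bears on it most is a 2.0-fold higher number from compound 2 to compound 3 (0.30 log units; within the scatter): compound 4, like compound 2, carries a substituted phenyl rather than a phenoxy group, though the ethoxy group of 3-ethoxyphenyl has no measured counterpart. A lower number is therefore expected for compound 4, with the step of a 1.7-fold lower number from compound 3 to compound 4 (0.23 log units; within the scatter) likely within the scatter. Compound 4 is estimated at 1300 nM, with a range from 500 nM to 3500 nM.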

Compound 4, half-maximal effective concentration: 3500 nM
For compound 4 the middle estimate is 2.7-fold (0.43 log units) below the measured one, within the range that was stated.
By their numbers in this assay, from the lowest: compounds 2, 3, 1 and 4 (each within the scatter of the next, the first and the last beyond it).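

Replacing 2-methoxyphenyl with 3-ethoxyphenyl on this aromatic carbon gives a 3.2-fold higher number from compound 2 to compound 4 (0.50 log units; beyond the scatter) and shows that a substituted phenyl here does not by itself keep the lower number. Against the other groups, a 1.6-fold higher number from compound 3 to compound 4 (0.20 log units; within the scatter) leaves 3-ethoxyphenyl unseparated from 4-methoxyphenoxy, and there is no change at the digits printed from compound 1 to compound 4 (within the scatter) when it replaces furan-3-yl. No measured evidence accounts for these results.

On these data alone, whether the gap between the two substituted phenyl groups follows the ethoxy chain or the place of the group on the ring remains open. A 3-methoxyphenyl or 2-ethoxyphenyl group would separate the two, and an amine or carboxylic acid on this ring is also untested among the compounds shown.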